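Removing the aryl group from a spiro-lactone dienone

The source may hold more compounds than are shown below. What is called first, only, known or untested is meant among the compounds shown, and "the series" means these compounds.

Measured so far:
compound 1 `O=C1C=CC2(C=C1)OC(=O)C(I)=C2c1ccccc1` — 41500 nM
compound 2 `O=C1C=CC2(C=C1)OC(=O)C(c1ccc(C(=O)O)cc1)=C2c1ccccc1` — 5950 nM

In a functional assay on MCF7 cells (Homo sapiens) for antiproliferative activity, read by MTT assay, with a stated time of 48 h (a lower number here means a stronger inhibitor, a higher number a weaker inhibitor), compound 1 gives 41500 nM, while compound 2 gives 5950 nM. Compound 2 therefore holds the lowest number of the two, and its nearest neighbour is compound 1. For the measured compounds named here, the only step known within this set is the one a 7.0-fold lower number from compound 1 to compound 2 (0.84 log units; beyond the scatter).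

Compound 3 `O=C1C=CC2(C=C1)OC(=O)C=C2c1ccccc1` differs from compound 2 by hydrogen in place of 4-carboxyphenyl on a double-bonded ring carbon. Going by the values given here, no measured pair shows exactly this exchange. What is known is that putting a 4-carboxyphenyl group in place of iodo lowered the number beyond the scatter; taking that same group away and leaving only hydrogen is expected to move the number back upward, probably by a step of similar size or larger, since even the iodo of compound 1 gave 41500 nM. The expected step is a 5.9-fold higher number from compound 2 to compound 3 (0.77 log units; beyond the scatter).

On that basis compound 3 is estimated to give about 35000 nM in this assay, with a plausible range from 9000 nM to 120000 nM.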

Compound 3, half-maximal inhibitory concentration: 6460 nM
Estimate against measurement, compound 3: 5.4-fold (0.73 log units) above; measured number outside the range, below it.
By their numbers in this assay, from the lowest: compounds 2 and 3 (each within the scatter of the next); then compound 1.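

In this assay, taking away the entire 4-carboxyphenyl group and leaving only hydrogen on the double-bonded ring carbon gives a 1.1-fold higher number from compound 2 to compound 3 (0.04 log units; within the scatter), so compounds 2 and 3 cannot be told apart in this test. The earlier step from iodo to 4-carboxyphenyl therefore did not show a need for the added aryl group: replacing iodo with hydrogen gives a 6.4-fold lower number from compound 1 to compound 3 (0.81 log units; beyond the scatter), and this is a change of a single atom for a single atom. Among these three compounds, it is the iodo of compound 1 that stands apart, while hydrogen and the much larger 4-carboxyphenyl group give numbers within the scatter of each other at this position.

Nothing available here explains why the iodo compound gives the higher number, or why such different groups as hydrogen and 4-carboxyphenyl match. On these data alone, it remains open whether a plain phenyl ring without its carboxylic acid, a methyl group, an amine or another halogen such as chlorine at this carbon would match hydrogen or iodo.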